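The compounds below may be only part of what the source reports. "The series", "measured", "known", "first", "only" and "open" are said of these compounds alone.

Measured compounds:
- Compound 1, `O=C(NCCCCc1ccccc1)n1nnc2ncccc21`: 0.0333 h
- Compound 2, `Cc1ccc(CNC(=O)n2c(N)nc3ccccc32)cc1`: 0.383 h

In a physicochemical assay for metabolic stability, read by HPLC, in phosphate buffer, at pH 7.4, tested at 10 uM (a higher number here means that the compound lasts longer, a lower number that the compound disappears faster), compound 2 gives 0.383 h, the highest of the two numbers measured, while compound 1 gives 0.0333 h, a gap that lies beyond the usual scatter. The two compounds share no single point of difference, so nothing is known about which part of either structure carries that gap.

Compound 3, `Nc1nc2ccccc2n1C(=O)NCc1ccccc1`, has not yet been measured in this assay. It differs from compound 2 in one place: hydrogen in place of methyl on an aromatic carbon. Among the compounds with values here, no measured pair shows this change, so its size has to be guessed. The expectation is a step of a 1.1-fold lower number from compound 2 to compound 3 (0.04 log units; within the scatter), that is, no change beyond the scatter in either direction. On that basis compound 3 is estimated at 0.35 h in this assay, with a range from 0.15 h to 0.8 h.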

Compound 3, half-life: 0.217 h
Compound 3: middle estimate off by 1.6-fold (0.21 log units), on the high side, within the range that was stated.
By their numbers in this assay, from the lowest: compound 1; then compounds 3 and 2 (each within the scatter of the next).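

Within the data shown here, this is the first reading of a change on the aromatic ring para to a large group, the 4-methylphenyl to phenyl change, and in this assay it gives a 1.8-fold lower number from compound 2 to compound 3 (0.25 log units; within the scatter). At this position, then, the methyl can give way to hydrogen with no shift beyond the scatter, so for this pair the methyl makes no measurable difference to the half-life. Nothing available explains the size of this step.

The compounds shown leave open whether a methoxy group, a chlorine atom or a carboxylic acid in the same place would move the half-life beyond the scatter. They also leave open whether the same exchange of methyl for hydrogen would read alike on a different core, such as that of compound 1.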